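Methyl in Place of Chloro on the Shared Core

The source may hold more compounds than are shown below. What is called first, only, known or untested is meant among the compounds shown, and "the series" means these compounds.

Measured compounds:
compound 1 `CN(Cc1ccc2nccn2c1)c1nnc(-c2ccc(-c3ccccc3F)cc2)o1` 1580 nM
compound 2 `Cc1nn(C)c(C)c1-c1ccc(-c2nnc(N(C)Cc3ccc4nccn4c3)o2)c(F)c1` 1260 nM
compound 3 `Cc1nn(C)c(C)c1-c1ccc(-c2nnc(N(C)Cc3ccc4nccn4c3)o2)c(Cl)c1` 79.4 nM

In an assay on isolated protein for inhibition of tyrosine-protein kinase receptor UFO (Homo sapiens), read by LC-MS (a higher number here means a weaker inhibitor, a lower number a stronger inhibitor), compound 3 gives the lowest number of the three, and its steps to compound 2 and to compound 1 are both beyond the scatter, so it stands as the strongest inhibitor of this set. Compound 4 `Cc1cc(-c2c(C)nn(C)c2C)ccc1-c1nnc(N(C)Cc2ccc3nccn3c2)o1` differs from compound 3 in one place: methyl in place of chloro on an aromatic carbon, ortho to a large group and meta to a 1,3,5-trimethyl-1H-pyrazol-4-yl group. Among the compounds with values here, only one measured step touches this position, a 16-fold lower number from compound 2 to compound 3 (1.20 log units; beyond the scatter), which shows that the substituent there matters a great deal. Within the data shown here, no measured pair shows methyl at this position, so the size of the new step is uncertain. Given that a small group at this carbon, as in compound 2 with 1260 nM, gave a much weaker inhibitor than compound 3 with 79.4 nM, compound 4 is expected to stay within reach of compound 3, perhaps a little weaker, with an expected step of a 1.6-fold higher number from compound 3 to compound 4 (0.21 log units; within the scatter). Compound 4 is therefore estimated at 130 nM in this assay, with a range from 40 nM to 450 nM.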

Compound 4, half-maximal inhibitory concentration: 79.4 nM
The estimate for compound 4 lay 1.6-fold (0.21 log units) above the measured number; measured number inside the range.
By their numbers in this assay, from the lowest: compounds 3 and 4 (each within the scatter of the next); then compounds 2 and 1 (each within the scatter of the next).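

In this assay, methyl in place of chloro on this aromatic carbon gives no change at the digits printed from compound 3 to compound 4 (within the scatter), so the two groups cannot be told apart at this position with the rest of the molecule held constant. Methyl in place of fluoro gives a 16-fold lower number from compound 2 to compound 4 (1.20 log units; beyond the scatter), which shows that the large step seen earlier with chloro is not tied to chloro alone; among the three compounds that differ only here, compound 2, with fluoro, is the one that stands apart. Nothing shown here gives a reason for this result. The compounds shown leave open how a methoxy, a trifluoromethyl or a nitrile on this carbon would compare with chloro and methyl, and whether hydrogen there would read like fluoro. They also leave open whether methyl and chloro would still match with an amine in place of the 1,3,5-trimethyl-1H-pyrazol-4-yl group.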